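The source may report more compounds than this note shows. Statements on the series, on what has been measured and on what is new or still open speak of the compounds shown alone.

Compound 1 `Nc1ccccc1NC(=O)c1ccc(Cn2cnc3c(Nc4ccccc4)nc(Cl)nc32)cc1` and compound 2 `Nc1ccccc1NC(=O)c1ccc(Cn2cnc3c(Nc4cccc(OC(F)(F)F)c4)nc(Cl)nc32)cc1` share one core and differ only at one aromatic carbon. In a functional assay on HCT-116 cells (Homo sapiens) for antiproliferative activity, read by CCK-8 assay, with a stated time of 72 h, tested at 2 uM (a lower number here means a weaker effect, a higher number a stronger effect of the compound at the concentration tested), compound 1 gives 71.4%, whereas compound 2 gives 1.6%, the lower of the two numbers shown; the single measured step, a number 69.8 percentage points lower from compound 1 to compound 2 (beyond the scatter), is a large loss of effect when trifluoromethoxy replaces hydrogen.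

Compound 3 `Nc1ccccc1NC(=O)c1ccc(Cn2cnc3c(Nc4cccc(Cl)c4)nc(Cl)nc32)cc1` is not yet measured. It differs from compound 2 by chloro in place of trifluoromethoxy on an aromatic carbon: a group of five heavy atoms is exchanged for a single chlorine at the same aromatic carbon. The one measured step bears on this only indirectly, since it compares a bare hydrogen with trifluoromethoxy, and no compound shown carries chloro at that position. Because the step of a number 69.8 percentage points lower from compound 1 to compound 2 (beyond the scatter) shows that a substituent at this carbon can abolish the effect, while compound 1 shows the unsubstituted ring is strongly active, the expectation for compound 3 is an intermediate number with wide uncertainty, and the step of a number 33.4 percentage points higher from compound 2 to compound 3 (beyond the scatter) is expected to be a recovery beyond the scatter. Compound 3 is therefore estimated at 35%, within a range from 5% to 70%.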

Compound 3, a percentage reported as inhibition, at one concentration (the size of the read-out at that concentration, not a potency): 56.2%
Estimate against measurement, compound 3: 21.2 percentage points below, and the stated range covers the measured number.
By their numbers in this assay, from the lowest: compound 2; then compound 3; then compound 1.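

The step of a number 54.6 percentage points higher from compound 2 to compound 3 (beyond the scatter) in this assay shows that not every substituent on this aromatic carbon, meta to a large group, abolishes the effect, as the trifluoromethoxy group alone might have suggested. The second step, a number 15.2 percentage points lower from compound 1 to compound 3 (beyond the scatter), is modest but beyond the scatter, so chloro in place of hydrogen keeps much of the effect without fully matching the unsubstituted ring. The position therefore accepts at least one substituent, and the outcome depends strongly on which group sits there, although nothing available here explains why these two groups behave so differently.

With only hydrogen, chloro and trifluoromethoxy shown at this carbon, it remains open whether the effect falls steadily as the substituent gains heavy atoms or whether trifluoromethoxy is a special case, and groups such as fluoro, methyl, methoxy or an amine at the same carbon would help separate these possibilities. From the compounds shown here alone, it is also open whether the same order would hold at other carbons of this ring, or across a range of concentrations rather than the single one tested.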